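The source may hold more compounds than are shown below. What is called first, only, known or untested is meant among the compounds shown, and "the series" means these compounds.

Measured compounds in a functional assay on isolated protein for inhibition of Glucose-dependent insulinotropic receptor (Rattus norvegicus), read by HTRF and cAMP accumulation; on this read-out lower numbers stand for smaller maximal responses and higher numbers for larger maximal responses:
compound 1 `Cc1nc(S(C)(=O)=O)ccc1Oc1ncnc(OC2CCN(C(=O)O[C@H](C)CF)CC2)c1F` gives 79%
compound 2 `Cc1nc(S(C)(=O)=O)ccc1Oc1ncnc(OC2CCN(C(=O)O[C@@H](C)CF)CC2)c1F` gives 84%
compound 3 `Cc1nc(S(C)(=O)=O)ccc1Oc1ncnc(OC2CCN(C(=O)SC3CC3)CC2)c1F` gives 80%

Compound 3 stands second highest of the three; its nearest neighbour is compound 1, a number 1 percentage points higher from compound 1 to compound 3 (within the scatter), and its furthest is compound 2, a number 4 percentage points lower from compound 2 to compound 3 (within the scatter). All three values lie within the scatter of one another.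

Compound 4 `Cc1nc(S(C)(=O)=O)ccc1Oc1ncnc(OC2CCN(C(=O)C3(F)CCC3)CC2)c1F` is the next step: a group of 5 heavy atoms (4 carbon, 1 fluorine; one four-membered non-aromatic ring of carbon only) in place of a group of 4 heavy atoms (3 carbon, 1 sulfur; one three-membered non-aromatic ring of carbon only), on a carbonyl carbon. Among the compounds with values here, the steps that bear on this are the two earlier exchanges on the carbonyl carbon, a number 1 percentage points higher from compound 1 to compound 3 (within the scatter) and a number 4 percentage points lower from compound 2 to compound 3 (within the scatter), both within the scatter; the configuration change a number 5 percentage points higher from compound 1 to compound 2 (within the scatter) was likewise within the scatter. No step beyond the scatter is therefore expected in this assay. Compound 4 is estimated at 80%, range 70% to 90%. This estimate means no change at the digits printed from compound 3 to compound 4 (within the scatter).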

Compound 4, largest response reached (reported as efficacy), in percent of the reference or control that the assay uses: 91%
Compound 4: the middle estimate sits 11 percentage points below what was measured, and the stated range ends below it.
By their numbers in this assay, from the lowest: compounds 1, 3, 2 and 4 (each within the scatter of the next, the first and the last beyond it).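

In this assay, within the data shown here, the group with one four-membered non-aromatic ring of carbon only, carrying fluorine on the carbonyl carbon, gives the first steps that lie beyond the scatter: a number 11 percentage points higher from compound 3 to compound 4 (beyond the scatter) and a number 12 percentage points higher from compound 1 to compound 4 (beyond the scatter). The remaining step stays within the scatter: a number 7 percentage points higher from compound 2 to compound 4 (within the scatter). The rise beyond the scatter therefore depends on the starting compound, even for a pair of identical constitution: the fact that compounds 1 and 2 differ only in the configuration as drawn

The compounds shown do not separate the contribution of the fluorine from that of the ring. A plain cyclobutyl or a cyclopentyl group on the same carbonyl carbon would address this.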